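A few compounds are considered here, and "the series" means these few. Any claim that something is new, unique, unknown or untested is made for them only; others in the source may bear on it.

In a functional assay on the whole organism (blood) with Rattus norvegicus as the target, with stated times of 24 h and 1 h, at a dose of 5 mg/kg by the intraperitoneal route (a higher number here means a stronger effect of the compound at the dose given, a lower number a weaker effect), three compounds have been measured:

Compound 1, `COc1ncccc1C(=O)NCCC1CCN(S(=O)(=O)NC(=O)NC2CCCCC2)CC1`: 33%
Compound 2, `Cc1ncccc1C(=O)NCCC1CCN(S(=O)(=O)NC(=O)NC2CCCCC2)CC1`: 16%
Compound 3, `O=C(NC1CCCCC1)NS(=O)(=O)N1CCC(CCNC(=O)c2cc(Cl)cc3cccnc23)CC1`: 52%

Compound 3 stands highest of the three, as the steps of a number 19 percentage points higher from compound 1 to compound 3 (beyond the scatter) and a number 36 percentage points higher from compound 2 to compound 3 (beyond the scatter) show. Compound 4, `O=C(NC1CCCCC1)NS(=O)(=O)N1CCC(CCNC(=O)c2cccc3c2OCCO3)CC1`, differs from compound 3 at the carbonyl carbon: 2,3-dihydro-1,4-benzodioxin-5-yl in place of 6-chloroquinolin-8-yl on a carbonyl carbon. Among the compounds with values here, the steps that bear on this are those at the same carbonyl carbon, a number 19 percentage points higher from compound 1 to compound 3 (beyond the scatter) and a number 36 percentage points higher from compound 2 to compound 3 (beyond the scatter), in which the 6-chloroquinolin-8-yl group gave the higher numbers; the smaller step of a number 17 percentage points lower from compound 1 to compound 2 (beyond the scatter) shows that the group here matters. Within the data shown here, no measured compound carries the 2,3-dihydro-1,4-benzodioxin-5-yl group, so a modest fall is expected, a number 22 percentage points lower from compound 3 to compound 4 (beyond the scatter), giving an estimate for compound 4 of 30%, between 10% and 55%.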

Compound 4, a percentage reported as activity, at one dose (the size of the read-out at that dose, not a potency): 34%
Compound 4: middle estimate off by 4 percentage points, on the low side; the range from low to high includes it.
By their numbers in this assay, from the lowest: compound 2; then compounds 1 and 4 (each within the scatter of the next); then compound 3.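

In this assay, the 2,3-dihydro-1,4-benzodioxin-5-yl group on the carbonyl carbon falls short of 6-chloroquinolin-8-yl (a number 18 percentage points lower from compound 3 to compound 4 (beyond the scatter)), yet it still exceeds 2-methylpyridin-3-yl (a number 18 percentage points higher from compound 2 to compound 4 (beyond the scatter)). Against 2-methoxypyridin-3-yl it shows no separation (a number 1 percentage points higher from compound 1 to compound 4 (within the scatter)), so having two rings in the group, as compound 3 and compound 4 both do, does not alone give the number of compound 3. No measurement given here accounts for these steps. The compounds shown leave open whether a quinolin-8-yl group without the chlorine would keep that number, and how a 2,3-dihydrobenzofuran-7-yl group would read at this carbon.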